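The source may hold more compounds than are shown below. What is called first, only, known or untested is meant among the compounds shown, and "the series" means these compounds.

Working notes on the series. Compound 1 `CCc1c(C(C)C)nc(C(C)C)c(C(C)O)c1-c1ccc(F)cc1O` and compound 2 `CCCc1c(C(C)C)nc(C(C)C)c(C(C)O)c1-c1ccc(F)cc1O` share the same core and differ only in the length of the saturated chain on it. In an assay on isolated protein for binding affinity to Glucagon receptor (Homo sapiens) (on this read-out lower numbers stand for stronger inhibition and higher numbers for weaker inhibition), compound 1 gives 2000 nM, and compound 2 gives 1000 nM. The step of a 2.0-fold lower number from compound 1 to compound 2 (0.30 log units; within the scatter) is within the scatter, so the two numbers of compound 2 and compound 1 sit within the scatter of each other and no ranking between them is claimed; compound 2 is simply the compound whose chain is extended.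

Compound 3 `CCCCCc1c(C(C)C)nc(C(C)C)c(C(C)O)c1-c1ccc(F)cc1O` is the next extension: ethyl in place of hydrogen on a saturated chain carbon, three bonds along the chain from an aromatic carbon. For the measured compounds named here, the one step that bears on it, a 2.0-fold lower number from compound 1 to compound 2 (0.30 log units; within the scatter), lengthened the same chain by one carbon and stayed within the scatter. For compound 3 in this assay the expected step is therefore a 1.4-fold lower number from compound 2 to compound 3 (0.15 log units; within the scatter), that is, no change beyond the scatter, with a slight lean toward a lower number. The estimate for compound 3 is 700 nM, with a range from 250 nM to 2500 nM.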

Compound 3, half-maximal inhibitory concentration: 2200 nM
Compound 3: middle estimate off by 3.1-fold (0.50 log units), on the low side; the range from low to high includes it.
By their numbers in this assay, from the lowest: compounds 2, 1 and 3 (each within the scatter of the next, the first and the last beyond it).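

In this assay, extending the chain further gives a 2.2-fold higher number from compound 2 to compound 3 (0.34 log units; beyond the scatter), so at this position a chain change now produces a step beyond the scatter, though only a modest one. Taken across the whole span, the change from compound 1 gives a 1.1-fold higher number from compound 1 to compound 3 (0.04 log units; within the scatter), so the ethyl and pentyl chains cannot be told apart here and the three compounds show no steady trend with chain length; only the propyl and pentyl chains of compound 2 and compound 3 are separated. Nothing at hand gives a reason for the higher number on the pentyl chain.

Going by these compounds, whether a butyl chain on the shared core reads with compound 2 or with compound 3 remains open. Also open, on these data alone, is whether a longer chain, or an amine or a carboxylic acid at the chain end, would move the number beyond the scatter from compound 2.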